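Series notes: hydroxy replaced by (4-chlorophenyl)amino

The source may report more compounds than this note shows. Statements on the series, on what has been measured and on what is new or still open speak of the compounds shown alone.

Within the data shown here, in a functional assay on Bel-7402 cells (Homo sapiens) for inhibition, read by MTT assay, with a stated time of 24 h, tested at 0.1 ug/mL (on this read-out lower numbers stand for less inhibition of growth and higher numbers for more inhibition of growth at the one concentration tested), compound 1 `CC(=O)SCCC(CCCCC(=O)O)SC(C)=O` gives 10.3%, the only number available, while compound 2 `O=C(CCCCC1CCSS1)Nc1ccc(Br)cn1` is recorded as "not active" (no number reported). Compound 3 `CC(=O)SCCC(CCCCC(=O)Nc1ccc(Cl)cc1)SC(C)=O` keeps the core of compound 1 and carries (4-chlorophenyl)amino in place of hydroxy on a carbonyl carbon. Among the measured compounds shown here, no measured pair shows this change, so the expectation in this assay is only a small rise, not clearly beyond the scatter. The estimated change is a number 4.7 percentage points higher from compound 1 to compound 3 (within the scatter). For compound 3 the expected value is 15%, with an estimated range of 3% to 35%.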

Compound 3, percent growth inhibition at one concentration: 9.96%
For compound 3 the middle estimate is 5 percentage points above the measured one; low and high end bracket the measured number.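

In this assay, among these compounds, the first step at this carbonyl carbon is a number 0.3 percentage points lower from compound 1 to compound 3 (within the scatter): the position accepts (4-chlorophenyl)amino in place of hydroxy, with its six-membered aromatic ring, without a change in the read-out. The low inhibition seen at the one concentration tested therefore does not depend on the free carboxylic acid. No measurement at hand accounts for this flat result. Open, as far as these compounds go, is whether a morpholine amide or a plain phenylamino group on this carbonyl carbon would read the same. Also open, from the compounds shown here alone, is whether free thiol groups in place of the thioacetates would move the read-out.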